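From Phenyl to 3-Amino-4-methoxyphenyl on a Shared Core

The source may hold more compounds than are shown below. What is called first, only, known or untested is meant among the compounds shown, and "the series" means these compounds.

Three compounds with a shared core have entries so far, but none of them gives an exact number. Compound 1 `COc1ccc(-c2c[nH]c(=O)n2-c2cc(OC)c(OC)c(OC)c2)cc1` has the entry "not determined" (no result reported) in a functional assay on K562 cells (Homo sapiens) for cytotoxicity, read by MTT assay, with a stated time of 48 h; on this read-out higher numbers stand for weaker inhibition and lower numbers for stronger inhibition. Compound 2 `COc1ccc(-c2c[nH]c(=O)n2-c2cc(OC)c(OC)c(OC)c2)cc1[N+](=O)[O-]` has the entry "not determined" (no result reported) in this assay. Compound 3 `COc1cc(-n2c(-c3ccccc3)cn(C(C)=O)c2=O)cc(OC)c1OC` gives > 50000 nM in this assay, and this is a limit of the assay, not a number. The whole measured picture therefore comes down to one entry: the limit of > 50000 nM in this assay, at which 1 of the 3 values shown sits.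

The next structure, compound 4 `COc1ccc(-c2cn(C(C)=O)c(=O)n2-c2cc(OC)c(OC)c(OC)c2)cc1N`, keeps the acetyl group of compound 3 and changes one substituent: 3-amino-4-methoxyphenyl in place of phenyl on an aromatic carbon. For the measured compounds named here, no step between measured compounds is available to size this change, so any forecast is uncertain. The expectation starts from compound 3 with its limit of > 50000 nM, and a large move in this assay toward lower numbers, meaning stronger inhibition, seems more likely than no change. The expected change is an at least 160-fold lower number from compound 3 to compound 4 (2.22 log units; beyond the scatter), and this estimate carries a wide margin. For compound 4 the estimated value is 300 nM, with an expected range from 10 nM to 8000 nM.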

Compound 4, half-maximal inhibitory concentration: 500 nM
Compound 4: the middle estimate sits 1.7-fold (0.22 log units) below what was measured; the range from low to high includes it.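

For the compounds shown here, the change from phenyl to 3-amino-4-methoxyphenyl on this aromatic carbon brings, in this assay, an at least 100-fold lower number from compound 3 to compound 4 (2.00 log units; beyond the scatter), and with it the first exact number on this shared core. This shows what the earlier entries could not: with the acetyl group kept in place, the group on this carbon, two ring bonds from the ring atom that bears the acetyl group, can decide whether the compound shows a measurable effect on these cells at all. The true size of the step remains unknown, because its starting point for compound 3 is a limit of the assay and not a number: the limit of > 50000 nM in this assay, at which 1 of the 4 values shown sits.

The new group differs from phenyl by carrying both an amino and a methoxy group, and the compounds shown cannot tell whether one of these or the pair accounts for the step. A plain 3-aminophenyl group or a 3-hydroxy-4-methoxyphenyl group at this position would address that question, while a propionyl chain in place of the acetyl group would test the other end of the core.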